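A few compounds are considered here, and "the series" means these few. Any claim that something is new, unique, unknown or untested is made for them only; others in the source may bear on it.

Of the compounds shown here, three have so far been tested in an assay on isolated protein for inhibition of MAP kinase-activated protein kinase 5 (Homo sapiens), read by mobility shift assay, tested at 30 uM; on this read-out lower numbers stand for less inhibition and higher numbers for more inhibition at the one concentration tested (going by the name of the read-out). Compound 1, `Cc1cc2c(c(NS(C)(=O)=O)nn2C)c(=O)[nH]1`, gives 0%. Compound 2, `COCCNc1nc(C)cc2nn(-c3ccccc3)c(N)c12`, gives 2%. Compound 3, `Nc1c2c(=O)[nH]c(-c3ccccc3)cc2nn1-c1ccccn1`, gives -1%. Within the data shown here, of these three numbers the one for compound 2 is the largest, but its nearest neighbour, compound 1, lies within the scatter of it, and so does the furthest, compound 3. The three values therefore cannot be told apart, and none of the compounds shows inhibition beyond the scatter at the single concentration tested.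

Compound 4, `Cc1cc2nn(-c3ccccc3)c(N)c2c(N2CCCCC2)n1`, has not yet been measured. It differs from compound 2 in one place: piperidin-1-yl in place of (2-methoxyethyl)amino on an aromatic carbon. Compound 2 gives 2% in this assay, which is no inhibition beyond the scatter, and nothing among the measured compounds offers a reason to expect this exchange to alter that picture. The step is therefore expected to be small, a number 1 percentage points higher from compound 2 to compound 4 (within the scatter), with no direction beyond the scatter. The estimate for compound 4 in this assay is 3%, with a range from -8% to 15%.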

Compound 4, a percentage reported as inhibition, at one concentration (the size of the read-out at that concentration, not a potency): 10%
Compound 4: the middle estimate sits 7 percentage points below what was measured, within the range that was stated.
By their numbers in this assay, from the lowest: compounds 3, 1, 2 and 4 (each within the scatter of the next, the first and the last beyond it).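

In this assay, among these compounds, the exchange of (2-methoxyethyl)amino for piperidin-1-yl on the aromatic carbon next to the ring nitrogen gives a number 8 percentage points higher from compound 2 to compound 4 (within the scatter), the first step between measured compounds that differ in one place. Among the compounds shown here, it shows that this position accepts an open chain with a hydrogen-bond donor or a six-membered non-aromatic ring with no such donor, and that this exchange alone does not move the read-out beyond the usual scatter, although compound 4, at 10%, holds the largest number so far. Nothing available explains the size of this step or shows whether it is real rather than scatter.

The compounds shown leave open whether another group on this carbon, such as a morpholine ring, a simple primary amine, a longer chain ending in a carboxylic acid, or an aromatic ring such as pyridine, would give a step beyond the scatter. They also leave open whether piperidin-1-yl would give the same result on a core carrying a different group in another place.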